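Bromo for fluoro in a chromone-ether amide series

This account rests on a few compounds, and the source may have more. Where it says the series, first, only, none or still open, it means among the compounds named here.

Measured compounds:
- compound 1, `O=C(COc1ccc2c(=O)ccoc2c1)Nc1cccc(NC(=O)c2ccc(F)cc2)c1`: 129 nM
- compound 2, `O=C(COc1ccc2c(=O)ccoc2c1)Nc1cccc(NC(=O)c2ccc(Br)cc2)c1`: 303 nM
- compound 3, `CN(C)c1ccc(C(=O)Nc2cc(F)cc(NC(=O)COc3ccc4c(=O)ccoc4c3)c2)cc1`: 49 nM

In an assay on isolated protein for inhibition of Rho-associated protein kinase 1 (Homo sapiens), read by scintillation counting, radiometric assay and 33P incorporation, with a stated time of 40 min, in the presence of a further agent that is not named here (on this read-out lower numbers stand for stronger inhibition and higher numbers for weaker inhibition), compound 1 gives 129 nM and compound 2 gives 303 nM. The two differ only as bromo in place of fluoro on an aromatic carbon, and that change made a 2.3-fold higher number from compound 1 to compound 2 (0.37 log units; beyond the scatter).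

Compound 3, `CN(C)c1ccc(C(=O)Nc2cc(F)cc(NC(=O)COc3ccc4c(=O)ccoc4c3)c2)cc1`, has the lowest number of the three in this assay, at 49 nM. How the core of compound 3 differs from the core of compound 1 is not broken down here.

Compound 4, `CN(C)c1ccc(C(=O)Nc2cc(Br)cc(NC(=O)COc3ccc4c(=O)ccoc4c3)c2)cc1`, has not been measured. It differs from compound 3 as bromo in place of fluoro on an aromatic carbon. Among the measured compounds shown here, this is the same kind of change as the one from compound 1 to compound 2, but not the same: in the earlier pair the place is para to a large group, whereas here the place is meta to two large groups.

For the measured compounds named here, with only one earlier instance, the expectation rests on compound 1 and compound 2, whose step was a 2.3-fold higher number from compound 1 to compound 2 (0.37 log units; beyond the scatter). On that basis compound 4 is expected to show a step of a 2.0-fold higher number from compound 3 to compound 4 (0.31 log units; beyond the scatter) in this assay, a rise of about the same size, with widened bounds because the place around the change is not the same. Compound 4 is thus estimated at 100 nM, between 45 nM and 230 nM.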

Compound 4, half-maximal inhibitory concentration: > 10000 nM
Compound 4 gave a limit, no number (the forecaster's own chance of this, stated with the estimate: 0%); middle value at least 100-fold (2.00 log units) from the limit.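

In this assay, bromo in place of fluoro on an aromatic carbon gives an at least 200-fold higher number from compound 3 to compound 4 (2.30 log units; beyond the scatter), so the size of the step on the core of compound 1 does not carry over to the core of compound 3: the same change on two cores in this assay, a 2.3-fold higher number (0.37 log units; beyond the scatter) from compound 1 to compound 2 and an at least 200-fold higher number (2.30 log units; beyond the scatter) from compound 3 to compound 4, at least 86-fold (1.93 log units) apart, beyond the scatter of two such steps

Compound 4 stands at a limit of the assay and not at a number, so the full size of its step stays unknown: the limit of > 10000 nM in this assay, at which 1 of the 4 values shown sits.

Both steps run the same way, but the two pairs differ both in the core and in the place of the change, so they do not show which of these sets the size of the step, and two pairs give no rule for the series.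

The compounds shown leave open whether the sharp rise belongs to bromo alone or would also appear with chloro or methyl at the same place on the core of compound 3. Also open, going by these compounds, is whether the step depends on the dimethylamino group of compound 3, which a matched fluoro and bromo pair carrying a morpholine or a plain hydrogen in its stead would test.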